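Methylphenyl for Bromophenyl: Expected Cytotoxicity of Compound 4

This account rests on a few compounds, and the source may have more. Where it says the series, first, only, none or still open, it means among the compounds named here.

Of the compounds shown here, three sharing one core have been tested in an ADME assay on MT4 cells (Homo sapiens) for cytotoxicity, read by MTT assay, with a stated time of 4 days; on this read-out higher numbers stand for lower toxicity in this test and lower numbers for higher toxicity in this test. Compound 1 `O=C(COc1cccc2ccccc12)N/N=C/c1ccc(O)cc1` gives 26.5 ug/mL. Compound 2 `O=C(COc1cccc2ccccc12)N/N=C/c1ccccc1[N+](=O)[O-]` gives 12.2 ug/mL. Compound 3 `O=C(COc1cccc2ccccc12)N/N=C/c1ccccc1Br` gives 11.4 ug/mL, the lowest of the three numbers; compound 2 sits within the scatter of it, as the step of a 1.1-fold lower number from compound 2 to compound 3 (0.03 log units; within the scatter) shows, whereas compound 1 sits further away, as a 2.3-fold lower number from compound 1 to compound 3 (0.37 log units; beyond the scatter) shows.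

Compound 4 `Cc1ccc(/C=N/NC(=O)COc2cccc3ccccc23)cc1` differs from compound 3 in one place: 4-methylphenyl in place of 2-bromophenyl on a carbon with a double bond to nitrogen. Among the measured compounds shown here, two measured steps bear on this change. Exchanging one aryl group for another, a 2.3-fold lower number from compound 1 to compound 3 (0.37 log units; beyond the scatter), gave a modest step beyond the scatter, while changing only the group on the ring, a 1.1-fold lower number from compound 2 to compound 3 (0.03 log units; within the scatter), gave none. A methylphenyl group has not been tried in this series, so the direction is uncertain. Compound 1 gave 26.5 ug/mL, whereas compound 2 and compound 3 gave lower numbers. A small move back toward higher numbers is therefore expected for compound 4, a 1.3-fold higher number from compound 3 to compound 4 (0.12 log units; within the scatter), though it may well stay within the scatter. Compound 4 is estimated at 15 ug/mL, with a likely range from 8 ug/mL to 30 ug/mL.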

Compound 4, half-maximal cytotoxic concentration: 83.9 ug/mL
For compound 4 the middle estimate is 5.6-fold (0.75 log units) below the measured one; measured number outside the range, above it.
By their numbers in this assay, from the lowest: compounds 3 and 2 (each within the scatter of the next); then compound 1; then compound 4.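

The aryl group on the carbon with a double bond to nitrogen turns out to matter far more in this assay than the first three compounds suggested: replacing 2-bromophenyl with 4-methylphenyl gives a 7.4-fold higher number from compound 3 to compound 4 (0.87 log units; beyond the scatter), a larger step than any seen among those compounds, and toward lower toxicity in this test. The group on the ring also matters on its own, since methyl in place of hydroxy on an aromatic carbon gives a 3.2-fold higher number from compound 1 to compound 4 (0.50 log units; beyond the scatter), again toward lower toxicity in this test. Nothing available explains why these steps are so large.

The names 2-bromophenyl and 4-methylphenyl differ in both the group and its number on the ring, and without 4-bromophenyl or 2-methylphenyl, the compounds shown cannot tell how much of the step belongs to each. As far as these compounds go, it also remains open whether a longer chain, as in 4-ethylphenyl, or an amine, as in 4-aminophenyl, would give a still higher number or a lower one.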